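A few compounds are considered here, and "the series" means these few. Any claim that something is new, unique, unknown or untested is made for them only; others in the source may bear on it.

Measured compounds in a functional assay on HepG2 cells (Homo sapiens) for antiproliferative activity, read by CCK-8 assay, with a stated time of 72 h, tested at 2 uM; a lower number here means a weaker effect, a higher number a stronger effect of the compound at the concentration tested:
compound 1 `Nc1ccccc1NC(=O)/C=C/c1ccc(Cn2cnc3c(NC4CCCCC4)nc(Cl)nc32)cc1` gives 3.83%
compound 2 `Nc1ccccc1NC(=O)/C=C/c1ccc(Cn2cnc3c(NCc4ccccc4)nc(Cl)nc32)cc1` gives 11.5%
compound 3 `CC1CCN(c2nc(Cl)nc3c2ncn3Cc2ccc(C(=O)Nc3ccccc3N)cc2)CC1` gives 1.22%

Compound 3 has the lowest of the three numbers in this assay; its nearest neighbour is compound 1, a gap within the scatter, while compound 2 lies beyond the scatter above it. For the measured compounds named here, the one measured step, a number 7.7 percentage points higher from compound 1 to compound 2 (within the scatter), concerns a different part of the molecule and lies within the scatter.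

Compound 4 `CC1CCN(c2nc(Cl)nc3c2ncn3Cc2ccc(/C=C/C(=O)Nc3ccccc3N)cc2)CC1` differs from compound 3 in one place: 2-((2-aminophenyl)carbamoyl)ethenyl in place of (2-aminophenyl)carbamoyl on an aromatic carbon. Going by the values given here, no measured step covers this change. The only indirect bearing comes from compound 1 and compound 2, which carry the 2-((2-aminophenyl)carbamoyl)ethenyl group and give low numbers in this assay, much like compound 3 with the (2-aminophenyl)carbamoyl group. A step no larger than the scatter is therefore expected for a number 2.8 percentage points higher from compound 3 to compound 4 (within the scatter), with no clear direction. Compound 4 is estimated at 4% in this assay, expected between 0% and 13%.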

Compound 4, a percentage reported as inhibition, at one concentration (the size of the read-out at that concentration, not a potency): 8.73%
Beside the measured number, compound 4's estimate is 4.7 percentage points below it; measured number inside the range.
By their numbers in this assay, from the lowest: compounds 3, 1, 4 and 2 (each within the scatter of the next, the first and the last beyond it).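

In this assay, the two side chains can now be compared directly on the same aromatic carbon, para to a large group: the change gives a number 7.5 percentage points higher from compound 3 to compound 4 (within the scatter) with 4-methylpiperidin-1-yl held constant, so lengthening (2-aminophenyl)carbamoyl to 2-((2-aminophenyl)carbamoyl)ethenyl has no readable effect here. With the ethenyl chain held constant, 4-methylpiperidin-1-yl in place of benzylamino gives a number 2.8 percentage points lower from compound 2 to compound 4 (within the scatter) and in place of cyclohexylamino gives a number 4.9 percentage points higher from compound 1 to compound 4 (within the scatter), so this exchange on the core cannot be read either. No available evidence bears on these results.

From the compounds shown here alone, whether a hydroxamic acid in place of the 2-aminophenyl amide, or a morpholine in place of 4-methylpiperidin-1-yl, would move the number beyond the scatter remains open. Readings at a single concentration also leave the potency of all four compounds open.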